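Fluorostilbenes: nuclear factor erythroid 2-related factor 2 activation

A few compounds are considered here, and "the series" means these few. Any claim that something is new, unique, unknown or untested is made for them only; others in the source may bear on it.

Measured so far:
compound 1 `COc1ccc(/C=C/c2cc(F)ccc2F)cc1`: 3200 nM
compound 2 `Fc1ccc(/C=C/c2ccccc2F)cc1`: 3600 nM
compound 3 `Fc1ccc(/C=C/c2cccc(F)c2)cc1`: 650 nM

In an assay on HepG2 cells for activation of nuclear factor erythroid 2-related factor 2 (Homo sapiens), read by a luciferase reporter, with a stated time of 5 h (on this read-out lower numbers stand for an effect already at smaller amounts and higher numbers for an effect only at larger amounts of compound), compound 3 gives the lowest number of the three, with compound 1 and compound 2 both beyond the scatter from it. Compound 4 `Fc1ccc(/C=C/c2cc(F)ccc2F)cc1` is the next step from compound 3: fluoro in place of hydrogen on an aromatic carbon. Within the data shown here, no measured pair shows this change directly, so its size is open; the two compounds already carrying fluoro ortho to the linker, compound 1 and compound 2, sit well above compound 3. The step from compound 3 to compound 4 is therefore expected to raise the number, a 3.1-fold higher number from compound 3 to compound 4 (0.49 log units; beyond the scatter), likely beyond the scatter. For compound 4 the expected value in this assay is 2000 nM, within 700 nM to 6000 nM.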

Compound 4, half-maximal effective concentration: 2900 nM
Estimate against measurement, compound 4: 1.5-fold (0.16 log units) below, within the range that was stated.
By their numbers in this assay, from the lowest: compound 3; then compounds 4, 1 and 2 (each within the scatter of the next).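

In this assay the position ortho to a group of 9 heavy atoms and para to a fluoro group is sensitive to substitution, with a 4.5-fold higher number from compound 3 to compound 4 (0.65 log units; beyond the scatter) for fluoro in place of hydrogen there. The other two steps separate nothing: fluoro in place of hydrogen gives a 1.2-fold lower number from compound 2 to compound 4 (0.09 log units; within the scatter) and fluoro in place of methoxy gives a 1.1-fold lower number from compound 1 to compound 4 (0.04 log units; within the scatter) in the same assay. Nothing available explains these steps.

Open, as far as these compounds go, is whether a larger group at this position, such as a chlorine atom, an amine or a carboxylic acid, would give a similar number to compound 4.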